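Bromo for Chloro, Tested Twice in Cells

The compounds below may be only part of what the source reports. "The series", "measured", "known", "first", "only" and "open" are said of these compounds alone.

Compound 1 `CN1C(=O)C2(C(C#N)=C(N)Oc3cc4oc(-c5ccccc5)cc(=O)c4c(O)c32)c2cc(Cl)ccc21` and compound 2 `CN1C(=O)C2(C(C#N)=C(N)Oc3cc4oc(-c5ccccc5)cc(=O)c4c(O)c32)c2cc(Br)ccc21` share one core and differ only in a halogen. In a functional assay on PC-3 cells (Homo sapiens) for antiproliferative activity, read by MTT assay, with a stated time of 48 h (a lower number here means a stronger inhibitor, a higher number a weaker inhibitor), compound 1 gives 21400 nM. In this assay compound 2 gives 20300 nM. The step of a 1.1-fold lower number from compound 1 to compound 2 (0.02 log units; within the scatter) comes from bromo in place of chloro on an aromatic carbon.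

Compound 3 `CCN1C(=O)C2(C(C#N)=C(N)Oc3cc4oc(-c5ccc(OC)cc5OC)cc(=O)c4c(O)c32)c2cc(Cl)ccc21` rests on a second core; how the two cores differ is not broken down here. In this assay compound 3 reaches only the limit of the assay, > 50000 nM. This is the limit of > 50000 nM in this assay, at which 1 of the 3 values shown sits.

Compound 4 `CCN1C(=O)C2(C(C#N)=C(N)Oc3cc4oc(-c5ccc(OC)cc5OC)cc(=O)c4c(O)c32)c2cc(Br)ccc21` stands to compound 3 as compound 2 stands to compound 1, through (bromo in place of chloro on an aromatic carbon), the same kind of change at a place described in the same words. Within the data shown here, the earlier step gives the only guide to what such a halogen swap does on these cores. The expected step from compound 3 to compound 4 is a step that the limit leaves unreadable from compound 3 to compound 4, because a 1.1-fold lower number from compound 1 to compound 2 (0.02 log units; within the scatter) stayed within the scatter and compound 3 already sits at > 50000 nM. Compound 4 is therefore estimated to give 60000 nM, expected between 30000 nM and 120000 nM.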

Compound 4, half-maximal inhibitory concentration: > 50000 nM
Compound 4: a limit, no number; the forecaster's own chance of this, stated with the estimate: 85%; the middle value lies beyond the limit too.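

Compound 3 and compound 4 both end at a limit in this assay rather than at a number, so no step can be read for bromo in place of chloro on this core: the limit of > 50000 nM in this assay, at which 2 of the 4 values shown sit.

The compounds shown leave open how strongly either compound acts in this assay, and whether this halogen swap changes anything on the core of compound 3.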